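This account rests on a few compounds, and the source may have more. Where it says the series, first, only, none or still open, it means among the compounds named here.

Of the compounds shown here, two built on a shared core have so far been tested in a functional assay on the whole organism with Mus musculus as the target; on this read-out higher numbers stand for an effect only at larger amounts of compound and lower numbers for an effect already at smaller amounts. Compound 1 `Cc1c(C)c2c(c(C)c1N)CC(C)(CSc1nccn1C)O2` gives 37.1 mg/kg, the higher of the two numbers. Compound 2 `Cc1c(C)c2c(c(C)c1N)CC(C)(CNCc1ccccc1)O2` gives 9.1 mg/kg, a lower number, and the gap between these two lies beyond the usual scatter. Compound 3 `Cc1c(C)c2c(c(C)c1N)CC(C)(CBr)O2` has not yet been measured. It differs from compound 1 in one place: bromo in place of (1-methyl-1H-imidazol-2-yl)sulfanyl on a saturated chain carbon bound to a saturated ring carbon. Going by the values given here, nothing measured so far shows what this particular exchange does, so no step beyond the scatter is expected, and the expected step is a 1.1-fold higher number from compound 1 to compound 3 (0.03 log units; within the scatter). Compound 3 is therefore estimated at 40 mg/kg, with a range from 15 mg/kg to 110 mg/kg.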

Compound 3, dose for 50% inhibition: 16 mg/kg
Beside the measured number, compound 3's estimate is 2.5-fold (0.40 log units) above it; measured number inside the range.
By their numbers in this assay, from the lowest: compounds 2 and 3 (each within the scatter of the next); then compound 1.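

In this assay, the group on this saturated chain carbon bound to a saturated ring carbon can be exchanged with a measurable result: a 2.3-fold lower number from compound 1 to compound 3 (0.37 log units; beyond the scatter) comes with bromo in place of (1-methyl-1H-imidazol-2-yl)sulfanyl. The five-membered aromatic ring is therefore not required for an effect in the whole animal, since a single bromine atom serves here. Nothing at hand explains why the number falls. Still open, going by these compounds, is how chloro, hydroxyl or a simple primary amine would behave on this same carbon.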